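Adding a Methyl Group to Compound 2

The source may report more compounds than this note shows. Statements on the series, on what has been measured and on what is new or still open speak of the compounds shown alone.

Measured in a functional assay on CHO cells for positive allosteric modulation of metabotropic glutamate receptor 2 (Homo sapiens), read by scintillation counting and GTPgammaS binding, with a stated time of 30 min; on this read-out higher numbers stand for larger maximal responses and lower numbers for smaller maximal responses:
compound 1 `CCCCn1ccc(-c2ccc(Oc3ccnc(C)c3)cc2)c(C#N)c1=O` gives 243%;
compound 2 `CCCCn1ccc(-c2ccc(Oc3cccnc3C)cc2)c(C#N)c1=O` gives 228%;
compound 3 `Cc1ncccc1Oc1ccc(-c2ccn(CC3CC3)c(=O)c2C#N)cc1` gives 155%.

Compound 2 stands second highest of these three numbers: the step of a number 15 percentage points lower from compound 1 to compound 2 (beyond the scatter) places it just below the top, and the step of a number 73 percentage points lower from compound 2 to compound 3 (beyond the scatter) places it far above the bottom.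

Compound 4 `CCCCn1ccc(-c2ccc(Oc3ccc(C)nc3C)cc2)c(C#N)c1=O` differs from compound 2 by methyl in place of hydrogen on an aromatic carbon. Of the measured steps, only a number 15 percentage points lower from compound 1 to compound 2 (beyond the scatter) also reworked the ring carried on the oxygen, and it was modest; the large step of a number 73 percentage points lower from compound 2 to compound 3 (beyond the scatter) concerned the chain on the ring nitrogen and does not bear on this change. A small step in this assay, possibly within the scatter, in either direction, is therefore expected. Compound 4 is estimated to give 220%, ranging from 180% to 260%. This estimate means an expected step of a number 8 percentage points lower from compound 2 to compound 4 (within the scatter).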

Compound 4, largest response reached (Emax), in percent of the reference or control that the assay uses: 239%
Beside the measured number, compound 4's estimate is 19 percentage points below it, and the stated range covers the measured number.
By their numbers in this assay, from the lowest: compound 3; then compound 2; then compounds 4 and 1 (each within the scatter of the next).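

In this assay, a methyl group added next to the ring nitrogen, on a ring that already carries one methyl, is more than tolerated: it gives a number 11 percentage points higher from compound 2 to compound 4 (beyond the scatter). With 2,6-dimethylpyridin-3-yl on the oxygen, the response can no longer be told apart from that of the 2-methylpyridin-4-yl ring, as shown by a number 4 percentage points lower from compound 1 to compound 4 (within the scatter). Nothing shown here accounts for these steps.

From the compounds shown here alone, whether an ethyl group or an amine at this same position would keep the response remains open. So does whether this added methyl would raise the lower response of compound 3, with its cyclopropyl-bearing chain.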